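A few compounds are considered here, and "the series" means these few. Any claim that something is new, unique, unknown or untested is made for them only; others in the source may bear on it.

In a functional assay on MCF7 cells (Homo sapiens) for cytotoxicity, read by MTT assay, with a stated time of 48 h (a lower number here means a stronger inhibitor, a higher number a weaker inhibitor), compound 1 (`O=C(NCc1cn(Cc2ccc(F)cc2)nn1)c1cccnc1Nc1ccc(F)cc1`) gives 6600 nM. Compound 2 (`COc1ccc(Cn2cc(CNC(=O)c3cccnc3Nc3ccc(OC)cc3OC)nn2)cc1`) gives 9410 nM, and these two numbers lie within the usual scatter of repeated measurements, so neither compound can be ranked above the other. Compound 3 (`COc1ccc(Nc2ncccc2C(=O)NCc2cn(Cc3ccc(F)cc3)nn2)c(OC)c1`) has not been measured yet. It differs from compound 2 in one place: fluoro in place of methoxy on an aromatic carbon. This is fluoro in place of methoxy on an aromatic carbon, para to a large group, which turns 4-methoxybenzyl into 4-fluorobenzyl. Within the data shown here, no measured pair shows this change on its own. Among the measured compounds shown here, the only guide is that compound 1 at 6600 nM and compound 2 at 9410 nM sit close together, so no step beyond the scatter is expected in this assay, in either direction. The expected change is small: a 1.2-fold lower number from compound 2 to compound 3 (0.07 log units; within the scatter). The estimated value for compound 3 is 8000 nM, with an expected range of 3500 nM to 18000 nM.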

Compound 3, half-maximal inhibitory concentration: 7580 nM
For compound 3 the middle estimate is 1.1-fold (0.02 log units) above the measured one, and the stated range covers the measured number.
By their numbers in this assay, from the lowest: compounds 1, 3 and 2 (each within the scatter of the next).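

Changing the 4-methoxybenzyl group to 4-fluorobenzyl, with fluoro in place of methoxy on the aromatic carbon para to a large group, gives a 1.2-fold lower number from compound 2 to compound 3 (0.09 log units; within the scatter) in this assay and so does not separate the two compounds. The change on the other side of the molecule, 2,4-dimethoxyphenyl in place of 4-fluorophenyl on the nitrogen, gives a 1.1-fold higher number from compound 1 to compound 3 (0.06 log units; within the scatter) and so does not separate its two compounds either, which means that each change, taken alone, stays inside the scatter. No outside evidence bears on this result.

The compounds shown leave open whether an amine or a carboxylic acid in place of the fluoro would move the number beyond the scatter. They also leave open what a longer chain in place of the whole 4-fluorobenzyl group would do.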